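This account rests on a few compounds, and the source may have more. Where it says the series, first, only, none or still open, it means among the compounds named here.

Measured in an ADME assay on cells (Hepatocyte, Mus musculus) for metabolic stability, with a stated time of 30 min; on this read-out lower numbers stand for a less stable compound and higher numbers for a more stable compound:
- compound 1 `O=c1cc(N2CCN(CC3CCC(NS(=O)(=O)c4ccccc4)CC3)CC2)sc2c([N+](=O)[O-])cc(C(F)(F)F)cc12`: 95.3%
- compound 2 `O=C(OC1CCC(CN2CCN(c3cc(=O)c4cc(C(F)(F)F)cc([N+](=O)[O-])c4s3)CC2)CC1)c1ccco1`: 0.6%
- compound 3 `O=C(OC1CCC(CN2CCN(c3cc(=O)c4cc(C(F)(F)F)cc([N+](=O)[O-])c4s3)CC2)CC1)c1ccc(C(F)(F)F)cc1`: 28.8%

Compound 3, at 28.8%, is second highest of the three, well under compound 1 at 95.3%, while compound 2 gives 0.6%. The next compound, compound 4 `O=C(OC1CCC(CN2CCN(c3cc(=O)c4cc(C(F)(F)F)cc([N+](=O)[O-])c4s3)CC2)CC1)c1cccs1`, has thiophen-2-yl in place of 4-(trifluoromethyl)phenyl on a carbonyl carbon.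

Going by the values given here, the most relevant evidence is a number 28.2 percentage points higher from compound 2 to compound 3 (beyond the scatter), the only measured step at this same place, where furan-2-yl gave way to 4-(trifluoromethyl)phenyl. The new group in compound 4 is a five-membered aromatic ring, which looks more like the furan-2-yl of compound 2 than the group it replaces. The other step, a number 94.7 percentage points lower from compound 1 to compound 2 (beyond the scatter), is far larger but concerns a different exchange, so it says little about this one. A single step is thin evidence, but it suggests that most of the gain seen in compound 3 will be lost. The expected change in this assay is therefore a downward one beyond the scatter, estimated as a number 23.8 percentage points lower from compound 3 to compound 4 (beyond the scatter). For compound 4 the estimated value is 5%, with an expected range from 0% to 20%.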

Compound 4, percent of the compound remaining: 1.8%
Compound 4: the middle estimate sits 3.2 percentage points above what was measured; the measured number falls inside the stated range.
By their numbers in this assay, from the lowest: compounds 2 and 4 (each within the scatter of the next); then compound 3; then compound 1.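

In this assay, replacing the six-membered aromatic ring on this carbonyl carbon with a five-membered one now has a second reading: the result is a number 27 percentage points lower from compound 3 to compound 4 (beyond the scatter), and the two five-membered rings cannot be told apart, with a number 1.2 percentage points higher from compound 2 to compound 4 (within the scatter). Among the three compounds that differ only at this carbonyl carbon, only 4-(trifluoromethyl)phenyl stands clear of the others, so furan-2-yl is not alone in giving a low number. The large exchange on the saturated ring carbon also holds with a second carbonyl partner, giving a number 93.5 percentage points lower from compound 1 to compound 4 (beyond the scatter), so the high number of the (phenylsulfonyl)amino compound is not tied to the furan-2-yl comparison alone.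

The compounds offer no measurement that explains any of these differences. On these data alone, it stays open whether the higher number of compound 3 comes from the six-membered ring itself or from its trifluoromethyl group, a question that an unsubstituted phenyl on the same carbonyl carbon could settle, and whether a simple amide link in place of the oxygen would behave more like compound 1.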